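Chloro to Fluoro in a Level Cytotoxicity Pair

A few compounds are considered here, and "the series" means these few. Any claim that something is new, unique, unknown or untested is made for them only; others in the source may bear on it.

In an ADME assay on MT4 cells (Homo sapiens) for cytotoxicity, read by MTT assay, with a stated time of 96 h (on this read-out higher numbers stand for lower toxicity in this test and lower numbers for higher toxicity in this test), compound 1 (`Cc1ccc(C2CC(c3ccc(OCc4ccccc4)cc3)=NN2c2ccc(S(N)(=O)=O)cc2)cc1`) gives 35000 nM and compound 2 (`NS(=O)(=O)c1ccc(N2N=C(c3ccc(OCc4ccccc4)cc3)CC2c2cccc(Cl)c2)cc1`) gives 36000 nM, which places compound 2 level with compound 1 within the scatter. Compound 3 (`NS(=O)(=O)c1ccc(N2N=C(c3ccc(OCc4ccccc4)cc3)CC2c2cccc(F)c2)cc1`) carries fluoro in place of chloro on an aromatic carbon. For the measured compounds named here, the only measured step that bears on this, a 1.0-fold higher number from compound 1 to compound 2 (0.01 log units; within the scatter), replaced a whole aryl group and stayed within the scatter, so no step beyond the scatter is expected in this assay. The expected change is a 1.0-fold lower number from compound 2 to compound 3 (0.01 log units; within the scatter). For compound 3 the estimated value is 35000 nM, with an expected range of 18000 nM to 70000 nM.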

Compound 3, half-maximal cytotoxic concentration: 65000 nM
For compound 3 the middle estimate is 1.9-fold (0.27 log units) below the measured one, and the stated range covers the measured number.
By their numbers in this assay, from the lowest: compounds 1, 2 and 3 (each within the scatter of the next).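

In this assay, fluoro in place of chloro on an aromatic carbon gives a 1.8-fold higher number from compound 2 to compound 3 (0.26 log units; within the scatter), and 3-fluorophenyl in place of 4-methylphenyl gives a 1.9-fold higher number from compound 1 to compound 3 (0.27 log units; within the scatter). This position therefore now shows a change of halogen alone, as well as exchanges of the whole aryl group, with no step beyond the scatter. Nothing measured here offers an explanation for these numbers. The compounds shown leave open whether an amine or a carboxylic acid in place of the halogen would also stay within the scatter.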